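Histamine H2 agonist series: dichlorophenyl replacing fluorophenyl

The source may hold more compounds than are shown below. What is called first, only, known or untested is meant among the compounds shown, and "the series" means these compounds.

Measured so far:
Compound 1 `N=C(NCCCc1c[nH]cn1)NCCC(c1ccccc1)c1ccccn1` gives 1 in a functional assay on cardiac atrium for agonist activity at histamine H2 receptor (Cavia porcellus); on this read-out higher numbers stand for larger maximal responses and lower numbers for smaller maximal responses.
Compound 2 `N=C(NCCCc1c[nH]cn1)NCCC(c1ccc(Cl)c(Cl)c1)c1ccccn1` gives 1 in this assay.
Compound 3 `N=C(NCCCc1c[nH]cn1)NCCC(c1ccccc1)c1ccc(F)cc1` gives 1 in this assay.

All three measured compounds reach the same maximal response in this assay. Among the measured compounds shown here, compound 3 stands level with compound 1 and compound 2; the step of no change at the digits printed from compound 1 to compound 3 (within the scatter) and the step of no change at the digits printed from compound 1 to compound 2 (within the scatter) are both within the usual scatter, and no compound can be called stronger or weaker than another.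

Compound 4 `N=C(NCCCc1c[nH]cn1)NCCC(c1ccccc1)c1ccc(Cl)c(Cl)c1` is not yet measured. It differs from compound 3 by 3,4-dichlorophenyl in place of 4-fluorophenyl on a saturated chain carbon bound to an aromatic carbon and a saturated chain carbon. The step bearing on this is no change at the digits printed from compound 1 to compound 2 (within the scatter), which puts the same 3,4-dichlorophenyl onto the same place and left the maximal response unchanged. Also no change at the digits printed from compound 1 to compound 3 (within the scatter) shows that exchanging the second aryl group at that place has given no change. No step beyond the scatter is therefore expected in this assay: compound 4 is expected at 1, within 0.9 to 1. The expected step is no change at the digits printed from compound 3 to compound 4 (within the scatter), which would be within the scatter.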

Compound 4, intrinsic activity: the largest response reached, as a fraction of the reference agonist's: 1
Compound 4: middle estimate and measured number agree at the digits printed; low and high end bracket the measured number.
By their numbers in this assay, from the lowest: compounds 1, 2, 3 and 4 (each within the scatter of the next).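

In this assay the exchange of 4-fluorophenyl for 3,4-dichlorophenyl gives no change at the digits printed from compound 3 to compound 4 (within the scatter) and shows that 3,4-dichlorophenyl is accepted on this saturated chain carbon with phenyl as the second aryl group, not only with pyridin-2-yl. With 3,4-dichlorophenyl held in place, the exchange of pyridin-2-yl for phenyl gives no change at the digits printed from compound 2 to compound 4 (within the scatter) and, with phenyl held in place, the exchange of pyridin-2-yl for 3,4-dichlorophenyl gives no change at the digits printed from compound 1 to compound 4 (within the scatter) in the same read-out, so neither pyridin-2-yl nor an unsubstituted phenyl is needed at this place. No supporting data are available to account for this flat result.

The four compounds leave open whether a non-aromatic group such as cyclohexyl at this place would keep the same maximal response. Also open, from the compounds shown here alone, is the effect of an aryl group bearing an amine or a carboxylic acid.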